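Bromo to iodo swap on the shared core: cytotoxicity notes

The source may report more compounds than this note shows. Statements on the series, on what has been measured and on what is new or still open speak of the compounds shown alone.

Measured so far:
compound 1, `Cc1cn(COC(CO)CO)c(=O)[nH]c1=O`: > 434000 nM
compound 2, `Cc1cc(=O)[nH]c(=O)n1COC(CO)CO`: > 434000 nM
compound 3, `Cc1c(Br)c(=O)[nH]c(=O)n1COC(CO)CO`: > 324000 nM

In a functional assay on HepG2 cells (Homo sapiens) for cytotoxicity (on this read-out higher numbers stand for lower toxicity in this test and lower numbers for higher toxicity in this test), compound 1 gives > 434000 nM, which is a limit of the assay and not a number. Compound 2 likewise gives > 434000 nM, again a limit. Compound 3 gives > 324000 nM, also a limit. So compound 3 stands where the other two stand: at a limit of this assay, with no number to rank it against compound 1 or compound 2.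

Within the data shown here, the only measured step in this assay, a step that the two limits leave unreadable from compound 2 to compound 3, cannot be read because the limit of > 434000 nM in this assay, at which 2 of the 3 values shown sit, marks its start and the limit of > 324000 nM in this assay, at which 1 of the 3 values shown sits, marks its end.

Compound 4, `Cc1c(I)c(=O)[nH]c(=O)n1COC(CO)CO`, differs from compound 3 by iodo in place of bromo on an aromatic carbon. Among the measured compounds shown here, the one step that bears on this change, the bromo-for-hydrogen step from compound 2 to compound 3, is unreadable, so no measured step sets a size here. With every value at a limit and no readable step in the series, no direction for the halogen exchange can be drawn from the data. Compound 4 is therefore expected to give a limit as well, with the step of an at least 1.0-fold lower number from compound 3 to compound 4 (0.03 log units; that floor lies within the scatter) expected to be none beyond the scatter. The estimate for compound 4 is 300000 nM, in the range 100000 nM to 900000 nM.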

Compound 4, half-maximal cytotoxic concentration: > 280000 nM
Compound 4: only a limit was reported (the forecaster's own chance of this, stated with the estimate: 80%); the middle value lies beyond the limit too.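

In this assay compound 4 gives > 280000 nM, a limit of the assay and not a number. Among these compounds, no step from compound 2 or compound 3 to compound 4 can be read. The compounds shown leave open whether bromo or iodo in place of hydrogen on the shared core changes this assay at all, and whether iodo and bromo differ.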